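The source may report more compounds than this note shows. Statements on the series, on what has been measured and on what is new or still open speak of the compounds shown alone.

The series shares one core and varies only the aromatic ring attached to it. Compound 1 `Fc1ccc2nc(-c3cnco3)n(C3CC3)c2c1` carries 1,3-oxazol-5-yl; in an ADME assay on cells for inhibition of cytochrome P450 11B1, mitochondrial (Homo sapiens), read by HPLC, with a stated time of 60 min (on this read-out higher numbers stand for weaker inhibition and lower numbers for stronger inhibition), compound 1 gives only a limit, > 10000 nM, and the limit of > 10000 nM in this assay, at which 1 of the 3 values shown sits, applies to it. Compound 2 `Fc1ccc2nc(-c3cn[nH]c3)n(C3CC3)c2c1` bears 1H-pyrazol-4-yl in place of 1,3-oxazol-5-yl; in this assay compound 2 gives 1670 nM, the lowest of the two measured numbers, and the change from compound 1 amounts to an at least 5.9-fold lower number from compound 1 to compound 2 (0.77 log units; beyond the scatter). Compound 3 `Fc1ccc2nc(-c3cncs3)n(C3CC3)c2c1` holds 1,3-thiazol-5-yl; in this assay compound 3 gives 4520 nM, which is an at least 2.2-fold lower number from compound 1 to compound 3 (0.34 log units; beyond the scatter) and also a 2.7-fold higher number from compound 2 to compound 3 (0.43 log units; beyond the scatter).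

Compound 4 `Fc1ccc2nc(-c3cnccn3)n(C3CC3)c2c1` is not yet measured. It differs from compound 2 by pyrazin-2-yl in place of 1H-pyrazol-4-yl on an aromatic carbon. All three measured steps bear on this change, since each exchanges one aromatic ring for another on an aromatic carbon of the core, and their sizes ran from modest to at least modest. Read from the side of compound 2, an at least 5.9-fold lower number from compound 1 to compound 2 (0.77 log units; beyond the scatter) and a 2.7-fold higher number from compound 2 to compound 3 (0.43 log units; beyond the scatter) both show that moving away from 1H-pyrazol-4-yl has so far gone with a higher number. Compound 4 is therefore expected to give a modestly higher number than compound 2, a step of a 2.1-fold higher number from compound 2 to compound 4 (0.32 log units; beyond the scatter). The estimate for compound 4 in this assay is 3500 nM, with a range from 1200 nM to 12000 nM.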

Compound 4, half-maximal inhibitory concentration: > 10000 nM
Compound 4 ended at the assay's limit; the forecaster's own chance of this, stated with the estimate: 15%; at least 2.8-fold (0.45 log units) between middle value and limit.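

In this assay compound 4 gives only a limit, and it is the second compound of the four to do so: the limit of > 10000 nM in this assay, at which 2 of the 4 values shown sit.

Against the two compounds with measured numbers, the change shows as an at least 5.9-fold higher number from compound 2 to compound 4 (0.77 log units; beyond the scatter) and as an at least 2.2-fold higher number from compound 3 to compound 4 (0.34 log units; beyond the scatter), so pyrazin-2-yl, the only six-membered aromatic ring of the four, reads weaker on this aromatic carbon between two ring nitrogen atoms than either 1H-pyrazol-4-yl or 1,3-thiazol-5-yl. The step between compound 1 and compound 4 cannot be read, with a limit on both sides, so pyrazin-2-yl and 1,3-oxazol-5-yl cannot be placed in order.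

The change from compound 2 to compound 4 alters ring size and the count of hydrogen-bond donors together, and the compounds shown do not separate the two. They also leave open how a pyridinyl ring, a 1H-imidazol-4-yl ring, or a 1H-pyrazol-4-yl ring carrying an amine or a carboxylic acid would read in this assay.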